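The source may hold more compounds than are shown below. What is called first, only, known or untested is meant among the compounds shown, and "the series" means these compounds.

Measured in a functional assay on PC-3 cells (Homo sapiens) for cytotoxicity, read by MTT assay, with a stated time of 72 h; on this read-out lower numbers stand for stronger inhibition and higher numbers for weaker inhibition:
- compound 1 `Cc1ccc(S(=O)(=O)n2cc(COC3=C/C(=N\c4ccccc4)c4ccccc4C3=O)nn2)cc1`: > 20000 nM
- compound 2 `CC(=O)c1ccc(/N=C2\C=C(OCc3cn(S(=O)(=O)c4ccc(C)cc4)nn3)C(=O)c3ccccc32)cc1`: 3910 nM

Going by the values given here, compound 2 holds the only true number so far, 3910 nM. The entry for compound 1, > 20000 nM, is a limit of the assay. Compound 3 `Cc1ccc(S(=O)(=O)n2cc(COC3=C/C(=N\c4ccc(I)cc4)c4ccccc4C3=O)nn2)cc1` differs from compound 2 by iodo in place of acetyl on an aromatic carbon, para to a large group. Among the compounds with values here, one measured step bears on this: an at least 5.1-fold lower number from compound 1 to compound 2 (0.70 log units; beyond the scatter), with acetyl in place of hydrogen on an aromatic carbon. Losing that acetyl should therefore give a moderately higher number in this assay, meaning weaker inhibition, and the expected change is a 2.3-fold higher number from compound 2 to compound 3 (0.36 log units; beyond the scatter). For compound 3 the estimate is 9000 nM, with an expected range of 3000 nM to 20000 nM.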

Compound 3, half-maximal inhibitory concentration: > 16300 nM
Compound 3 gave a limit, no number; the forecaster's own chance of this, stated with the estimate: 30%; middle value at least 1.8-fold (0.25 log units) from the limit.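

Iodo in place of acetyl at this position, para to a large group, gives an at least 4.1-fold higher number from compound 2 to compound 3 (0.62 log units; beyond the scatter) in this assay, so acetyl is now favoured over a second group, not only over hydrogen. For compound 3, > 16300 nM is a limit and not a number. The step from compound 1 to compound 3 cannot be read, since both values are limits.

The compounds shown leave open how an amine, a carboxylic acid or a longer ketone chain would fare at this position. From the compounds shown here alone, the true values of compound 1 and compound 3 also remain open.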